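Adding a nitro group to compound 1

The compounds below may be only part of what the source reports. "The series", "measured", "known", "first", "only" and "open" are said of these compounds alone.

Compound 1 `CCn1cc(-c2nc3ccccc3o2)c(=O)c2cc(F)c(Cl)cc21` gives 10200 nM
Compound 2 `CCn1cc(-c2nc3ccccc3o2)c(=O)c2cc(F)c(N3CCN(C)CC3)cc21` gives 87400 nM
Compound 3 `CCn1cc(-c2nc3ccc([N+](=O)[O-])cc3[nH]2)c(=O)c2cc(F)c(N3CCNC(C)C3)c(F)c21` gives 2300 nM

In a functional assay on KB cells (Homo sapiens) for cytotoxicity, read by MTT assay, with a stated time of 48 h (a higher number here means a weaker inhibitor, a lower number a stronger inhibitor), compound 1 holds the middle place of the three numbers, with compound 3 lower and compound 2 higher. Compound 4 `CCn1cc(-c2nc3ccc([N+](=O)[O-])cc3o2)c(=O)c2cc(F)c(Cl)cc21` differs from compound 1 by a single change, nitro in place of hydrogen on an aromatic carbon and the rest of the core stays the same. Within the data shown here, no measured step adds a nitro group to a compound. Among the measured compounds shown here, the one measured step, an 8.6-fold higher number from compound 1 to compound 2 (0.93 log units; beyond the scatter) replaces chloro with 4-methylpiperazin-1-yl, and it shows only that one change can move this number clearly. Compound 3 also carries a nitro group and gives 2300 nM in this assay but it differs from compound 1 in more than one place, which makes it a weak hint. A small move toward a lower number is therefore expected. The expected step is a 1.9-fold lower number from compound 1 to compound 4 (0.27 log units; within the scatter) in this assay as an estimate only. Compound 4 is estimated at 5500 nM with an expected range from 1800 nM to 17000 nM in this assay on this reading.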

Compound 4, half-maximal inhibitory concentration: 500 nM
Compound 4: middle estimate off by 11-fold (1.04 log units), on the high side, and the stated range ends above it.
By their numbers in this assay, from the lowest: compound 4; then compound 3; then compound 1; then compound 2.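

In this assay the new step (a 20-fold lower number from compound 1 to compound 4 (1.31 log units; beyond the scatter)) shows that this carbon, on the six-membered aromatic ring of carbon only, is a place where one added nitro group can move the number strongly toward a stronger inhibitor. Before this, the only single change with a measured step was the replacement of chloro by 4-methylpiperazin-1-yl (an 8.6-fold higher number from compound 1 to compound 2 (0.93 log units; beyond the scatter)), which moved the number the opposite way. No measurement available here accounts for the size of the new step.

As far as these compounds go, whether this gain is specific to nitro, or would also appear with another group on this carbon, such as an amine or a nitrile, remains open. So does whether nitro would give a similar step on a compound carrying 4-methylpiperazin-1-yl in place of chloro.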